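The source may report more compounds than this note shows. Statements on the series, on what has been measured and on what is new or still open speak of the compounds shown alone.

Working notes on the series. Compound 1 `CC(C)n1ncc2c(C(=O)NCc3cn(-c4ccccc4)nn3)cccc21` is the unsubstituted aryl member. In a functional assay on MGC-803 cells (Homo sapiens) for inhibition, read by MTT assay, with a stated time of 72 h (a lower number here means a stronger inhibitor, a higher number a weaker inhibitor), compound 1 reaches only the limit of the assay, > 40000 nM. Compound 2 `Cc1ccc(-n2cc(CNC(=O)c3cccc4c3cnn4C(C)C)nn2)c(C)c1` carries 2,4-dimethylphenyl in place of phenyl on an aromatic nitrogen; in this assay compound 2 likewise gives only the limit, > 40000 nM. Compound 3 `Cc1ccc(-n2cc(CNC(=O)c3cccc4c3cnn4C(C)C)nn2)cc1` in this assay also gives only the limit, > 40000 nM. Hence (the limit of > 40000 nM in this assay, at which 3 of the 3 values shown sit), and the steps a step that the two limits leave unreadable from compound 1 to compound 2, a step that the two limits leave unreadable from compound 1 to compound 3 and a step that the two limits leave unreadable from compound 2 to compound 3 cannot be read in size or direction. Compound 3 therefore stands at the limit together with the two other values shown, with nothing to set it apart from them. Compound 4 `Cc1cccc(-n2cc(CNC(=O)c3cccc4c3cnn4C(C)C)nn2)c1` differs from compound 3 by 3-methylphenyl in place of 4-methylphenyl on an aromatic nitrogen. Among the compounds with values here, no measured step bears on this change in a readable way, since every value shown is a limit. Compound 4 is therefore expected to remain at or near the limit of this assay, the step that the limit leaves unreadable from compound 3 to compound 4 being expected to show no readable change. Compound 4 is estimated at 60000 nM, within a range of 20000 nM to 200000 nM.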

Compound 4, half-maximal inhibitory concentration: > 40000 nM
Compound 4 was reported as a limit; the forecaster's own chance of this, stated with the estimate: 85%; the middle value lies beyond the limit too.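

Within the data shown here, compound 4 joins compound 1, compound 2 and compound 3 at the limit, so no step among them can be read in size or direction: the limit of > 40000 nM in this assay, at which 4 of the 4 values shown sit. The compounds shown leave open whether any aryl group on the shared core gives a measurable value in this assay at all.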